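Swapping the aryl ether on a cell-active inhibitor

A few compounds are considered here, and "the series" means these few. Any claim that something is new, unique, unknown or untested is made for them only; others in the source may bear on it.

Among the measured compounds shown here, compound 2 `CC(C)[C@H](NC(=O)COc1cccc2ccccc12)C(=O)N[C@@H](CC(=O)O)C(=O)COc1c(F)cccc1F` is the only compound with a number in a functional assay on Jurkat cells (Homo sapiens); on this read-out lower numbers stand for stronger inhibition and higher numbers for weaker inhibition: compound 2 gives 2040 nM. Compound 1 `CC(C)[C@H](NC(=O)COc1cccc2ccccc12)C(=O)N[C@@H](CC(=O)O)C(=O)COc1ccccc1C(F)(F)F` sits at an assay limit (the limit of > 100000 nM in this assay, at which 1 of the 2 values shown sits); in this assay compound 1 gives > 100000 nM, a limit rather than a number. For the measured compounds named here, the one measured step at the same place is an at least 49-fold lower number from compound 1 to compound 2 (1.69 log units; beyond the scatter). Compound 3 `CC(C)[C@H](NC(=O)COc1cccc2ccccc12)C(=O)N[C@@H](CC(=O)O)C(=O)COc1ccc([N+](=O)[O-])cc1F` carries 2-fluoro-4-nitrophenyl in place of 2,6-difluorophenyl on an oxygen on a saturated carbon. That earlier step shows that the group on this oxygen can move the read-out strongly, but it does not tell which way 2-fluoro-4-nitrophenyl will go, so only a small change is expected, a 1.4-fold lower number from compound 2 to compound 3 (0.13 log units; within the scatter). Compound 3 is estimated at 1500 nM, with a range from 300 nM to 8000 nM.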

Compound 3, half-maximal inhibitory concentration: 30300 nM
Estimate against measurement, compound 3: 20-fold (1.31 log units) below, outside the stated range (above it).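

In this assay, replacing 2,6-difluorophenyl with 2-fluoro-4-nitrophenyl on this oxygen weakens inhibition, giving a 15-fold higher number from compound 2 to compound 3 (1.17 log units; beyond the scatter). Even so, 2-fluoro-4-nitrophenyl outperforms 2-(trifluoromethyl)phenyl, with an at least 3.3-fold lower number from compound 1 to compound 3 (0.51 log units; beyond the scatter). Among these three groups, 2,6-difluorophenyl therefore gives the strongest inhibition, although the gap to compound 1 has no upper end, since compound 1 sits at a limit: the limit of > 100000 nM in this assay, at which 1 of the 3 values shown sits.

Compound 3 differs from compound 2 by both a lost fluorine and an added nitro group, and the compounds shown do not separate these two changes. Going by these compounds, how 2-fluorophenyl, or a ring carrying a nitrile instead of the nitro group, would read out remains open.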